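Swapping the aryl group: from compound 2 to compound 3

The compounds below may be only part of what the source reports. "The series", "measured", "known", "first", "only" and "open" are said of these compounds alone.

Compound 1 `O=C(NO)c1ccc(/C=C/c2ccnc(-c3ccccc3O)c2)cc1` gives 47 nM in an assay on isolated protein for inhibition of protein deacetylase HDAC6 (Homo sapiens), read by fluorescence, with a stated time of 15 min; on this read-out higher numbers stand for weaker inhibition and lower numbers for stronger inhibition. Going by the values given here, compound 2 `COc1ccc(-c2cc(/C=C/c3ccc(C(=O)NO)cc3)ccn2)cc1` gives 110 nM in this assay and stands highest of the two numbers so far. Among the compounds with values here, the one measured step, a 2.3-fold higher number from compound 1 to compound 2 (0.37 log units; beyond the scatter), exchanged one six-membered aryl for another at the same place. Compound 3 `O=C(NO)c1ccc(/C=C/c2ccnc(-c3ccsc3)c2)cc1` carries thiophen-3-yl in place of 4-methoxyphenyl on an aromatic carbon. Within the data shown here, that step is the only one bearing on this change, and it was modest; a five-membered ring enters here, so the expected step is a 1.4-fold lower number from compound 2 to compound 3 (0.14 log units; within the scatter), small and toward stronger inhibition if anything. Compound 3 is therefore expected at 80 nM, with a range from 35 nM to 180 nM.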

Compound 3, half-maximal inhibitory concentration: 54 nM
Compound 3: the middle estimate sits 1.5-fold (0.17 log units) above what was measured; the range from low to high includes it.
By their numbers in this assay, from the lowest: compounds 1 and 3 (each within the scatter of the next); then compound 2.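

At this place, on an aromatic carbon next to the ring nitrogen, a five-membered ring carrying sulfur is tolerated: thiophen-3-yl gives a 2.0-fold lower number from compound 2 to compound 3 (0.31 log units; beyond the scatter). Against the hydroxyl-bearing aryl group it gives a 1.1-fold higher number from compound 1 to compound 3 (0.06 log units; within the scatter), so among these compounds neither a six-membered aryl ring nor a hydroxyl is needed to reach the level of compound 1. Nothing available explains either step.

Open, on these data alone, is whether a furan-3-yl or pyridin-3-yl ring would hold this level. Also open, as far as these compounds go, is how a carboxylic acid or an aminomethyl group on the thiophene would shift it.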